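A Fluorine Added to the Shared Core

This account rests on a few compounds, and the source may have more. Where it says the series, first, only, none or still open, it means among the compounds named here.

For the measured compounds named here, compound 2 `O=C1/C(=C/c2ccccc2)CCc2ccccc21` is the only compound here with a numbered result: in a functional assay on P388 cells (Mus musculus) for inhibition (a higher number here means a weaker inhibitor, a lower number a stronger inhibitor), compound 2 gives 30200 nM. Compound 1 `O=C1/C(=C/c2ccc(F)cc2)Cc2ccccc21`, built on a different core, reaches only a limit of the assay, and in this assay compound 1 gives > 50000 nM. Compound 3 `O=C1/C(=C/c2cccc(F)c2)CCc2ccccc21` is not yet measured; it differs from compound 2 by fluoro in place of hydrogen on an aromatic carbon. Going by the values given here, no measured pair shows this change, so the step is expected to stay within the usual scatter, a 1.1-fold higher number from compound 2 to compound 3 (0.03 log units; within the scatter). Compound 3 is therefore estimated at 32000 nM, within 12000 nM to 80000 nM.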

Compound 3, half-maximal inhibitory concentration: 31100 nM
The estimate for compound 3 lay 1.0-fold (0.01 log units) above the measured number; measured number inside the range.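

In this assay, for the compounds shown here, this is the first measured look at the change, and it gives a 1.0-fold higher number from compound 2 to compound 3 (0.01 log units; within the scatter). Placing fluoro on this aromatic carbon, meta to a large group, therefore leaves the reading of the shared core where it was. Compound 2 and compound 3 both still give real numbers rather than reaching the limit of the assay: the limit of > 50000 nM in this assay, at which 1 of the 3 values shown sits.

The compounds shown leave open whether fluoro elsewhere on this ring would behave the same way. They also leave open whether a different group at this place, such as an amine or a carboxylic acid, would move the number.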